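The source may report more compounds than this note shows. Statements on the series, on what has been measured and on what is new or still open speak of the compounds shown alone.

In a functional assay on HepG2 cells (Homo sapiens) for inhibition, read by MTT assay, with a stated time of 24 h (on this read-out higher numbers stand for weaker inhibition of growth and lower numbers for stronger inhibition of growth), compound 1 (`COc1cc(C(=O)n2c(-c3cn(C)c4ccccc34)nc3ccccc32)cc(OC)c1OC`) gives 4300 nM and compound 2 (`COc1ccc2c(c1)c(-c1nc3ccccc3n1C(=O)c1ccc(OC)c(OC)c1)cn2C`) gives 5100 nM so the two stand within the usual scatter of each other. Compound 3 (`COc1ccc2c(c1)c(-c1nc3ccccc3n1C(=O)c1cc(OC)c(OC)c(OC)c1)cn2C`) differs from compound 2 in one place, where methoxy takes the place of hydrogen on an aromatic carbon (methoxy in place of hydrogen on an aromatic carbon). Among the measured compounds shown here, no measured pair yet shows a single change like this in this assay so its size is uncertain, and no shift beyond the scatter is expected. The expected step of a 1.3-fold lower number from compound 2 to compound 3 (0.11 log units; within the scatter) is therefore small. Compound 3 is estimated at 4000 nM with 1500 nM to 10000 nM as the expected range.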

Compound 3, concentration for 50% growth inhibition: 3800 nM
Compound 3: the middle estimate sits 1.1-fold (0.02 log units) above what was measured; the measured number falls inside the stated range.
By their numbers in this assay, from the lowest: compounds 3, 1 and 2 (each within the scatter of the next).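

In this assay, putting methoxy in place of hydrogen on an aromatic carbon, ortho to a methoxy group and meta to a large group, gives a 1.3-fold lower number from compound 2 to compound 3 (0.13 log units; within the scatter), so this position accepts the added group with no shift that can be told from the scatter. The same replacement at a different aromatic carbon gives a 1.1-fold lower number from compound 1 to compound 3 (0.05 log units; within the scatter), so neither place stands out. No supporting data bear on these small steps. From the compounds shown here alone, whether an amine or a carboxylic acid at this position would move the number beyond the scatter stays open.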